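Adding a hydroxy group to compound 2

A few compounds are considered here, and "the series" means these few. Any claim that something is new, unique, unknown or untested is made for them only; others in the source may bear on it.

In an ADME assay on microsomes from liver (Rattus norvegicus) for metabolic stability, with a stated time of 10 min, tested at 0.5 uM (a lower number here means that less of the compound is left, a higher number that more of the compound is left), compound 1 (`C[C@H](NC(=O)c1cnn2cccnc12)c1cc2cc(Cl)cc(C(=O)O)c2o1`) gives 94% and compound 2 (`O=C(O)c1cc(Cl)cc2cc(CNC(=O)c3cnn4cccnc34)oc12`) gives 100% of the compound remaining, so these two lie within the usual scatter of each other.

Compound 3 (`O=C(O)c1c(O)c(Cl)cc2cc(CNC(=O)c3cnn4cccnc34)oc12`) carries one change on compound 2: hydroxy in place of hydrogen on an aromatic carbon in short, hydroxy in place of hydrogen on an aromatic carbon, ortho to a carboxy group and ortho to a chloro group.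

For the measured compounds named here, the only measured step is a number 6 percentage points higher from compound 1 to compound 2 (within the scatter) and it lies on a saturated chain carbon, not on the aromatic carbon changed here. Going by the values given here, no measured compound carries this hydroxy, so the guidance is weak. In this assay the expected change is a number 7 percentage points lower from compound 2 to compound 3 (within the scatter) and no step beyond the scatter is expected. Compound 3 is estimated at 93% within a range of 80% to 100% of the compound remaining.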

Compound 3, percent of the compound remaining: 88%
Compound 3: middle estimate off by 5 percentage points, on the high side, within the range that was stated.
By their numbers in this assay, from the lowest: compounds 3, 1 and 2 (each within the scatter of the next, the first and the last beyond it).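

In this assay, placing a hydroxy group on this aromatic carbon, ortho to a carboxy group and ortho to a chloro group, gives a number 12 percentage points lower from compound 2 to compound 3 (beyond the scatter). For the compounds shown here, the only earlier step lay within the scatter and involved a saturated chain carbon, so this is the first sign that a change on the aromatic ring can shift this read-out measurably, although the step is modest. No measurement at hand explains the lower number.

On these data alone, it remains open whether the step belongs to the hydroxy group itself or would also appear with another group on this carbon, such as methoxy or an amine. As far as these compounds go, it is also open whether the same hydroxy group would give a similar step on compound 1, which keeps the methyl on its chain carbon.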